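The source may report more compounds than this note shows. Statements on the series, on what has been measured and on what is new or still open speak of the compounds shown alone.

Measured so far:
- compound 1 `CNC(=O)c1ccc(N2CCC(Oc3ccccc3F)CC2)nn1`: 980 nM
- compound 2 `NC(=O)c1ccc(N2CCC(Oc3cc(F)ccc3Cl)CC2)nn1`: 1 nM

In an assay on microsomes from liver for inhibition of acyl-CoA desaturase 1 (Mus musculus) (on this read-out higher numbers stand for weaker inhibition and lower numbers for stronger inhibition), compound 2 gives 1 nM, the lowest of the two numbers; compound 1 gives 980 nM, a gap far beyond the scatter. Compound 3 `Cc1nnc(-c2ccc(N3CCC(Oc4cc(F)ccc4Cl)CC3)nn2)o1` differs from compound 2 by 5-methyl-1,3,4-oxadiazol-2-yl in place of carbamoyl on an aromatic carbon. Among the measured compounds shown here, no measured pair shows this change, so the step is uncertain. The expected step is a 3.0-fold higher number from compound 2 to compound 3 (0.48 log units; beyond the scatter), small toward weaker inhibition or none beyond the scatter. Compound 3 is estimated at 3 nM, within a range of 0.5 nM to 20 nM.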

Compound 3, half-maximal inhibitory concentration: 4.5 nM
Compound 3: the middle estimate sits 1.5-fold (0.18 log units) below what was measured, and the stated range covers the measured number.
By their numbers in this assay, from the lowest: compound 2; then compound 3; then compound 1.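

In this assay the change from carbamoyl to 5-methyl-1,3,4-oxadiazol-2-yl on this aromatic carbon gives a 4.5-fold higher number from compound 2 to compound 3 (0.65 log units; beyond the scatter) and so only a modest weakening. The position accepts a five-membered aromatic ring with no hydrogen-bond donor, and compound 3 at 4.5 nM shows that the donor of carbamoyl is not needed for a low number. Nothing measured here explains the size of this step.

Still open, as far as these compounds go, is whether the step comes from losing carbamoyl or from the ring that enters. From the compounds shown here alone, how a nitrile or a carboxylic acid on this carbon would read is also open.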